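The source may report more compounds than this note shows. Statements on the series, on what has been measured and on what is new or still open speak of the compounds shown alone.

In a functional assay on RT-112 cells (Homo sapiens) for antiproliferative activity, read by MTT assay, with a stated time of 72 h (a lower number here means a stronger inhibitor of growth, a higher number a weaker inhibitor of growth), three compounds sharing one core have been measured. Compound 1 `COc1cc(Nc2ncnc3c(NC(=O)Nc4cccc(Oc5ccccc5)c4)cccc23)cc(OC)c1` gives 14000 nM, compound 2 `COc1cc(Nc2ncnc3c(NC(=O)Nc4ccc(C)c(C)c4)cccc23)cc(OC)c1` gives 8.8 nM, and compound 3 `COc1cc(Nc2ncnc3c(NC(=O)Nc4ccccc4Cl)cccc23)cc(OC)c1` gives 356 nM, so compound 3 stands between the other two and well apart from each. The next structure is compound 4 `COc1cc(Nc2ncnc3c(NC(=O)Nc4ccc(Cl)c(C(F)(F)F)c4)cccc23)cc(OC)c1`, and the change is 4-chloro-3-(trifluoromethyl)phenyl in place of 2-chlorophenyl on an amide-type nitrogen. Among the measured compounds shown here, the one measured step at this place is a 40-fold higher number from compound 2 to compound 3 (1.61 log units; beyond the scatter), a large step beyond the scatter. Compound 2 at 8.8 nM shows that this place can carry a far lower number. Compound 1 at 14000 nM shows that it can also carry a far higher one, so the direction is not secure. A moderate move toward a lower number, smaller than the measured step, is expected in this assay. The expected step is a 4.5-fold lower number from compound 3 to compound 4 (0.65 log units; beyond the scatter). For compound 4 the estimated value is 80 nM, with an expected range of 10 nM to 800 nM.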

Compound 4, concentration for 50% growth inhibition: > 20000 nM
Compound 4: only a limit was reported; the forecaster's own chance of this, stated with the estimate: 5%; middle value at least 250-fold (2.39 log units) away from the limit.
By their numbers in this assay, from the lowest: compound 2; then compound 3; then compound 1. At a limit, above all of these: compound 4.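

In this assay, compound 4 gives > 20000 nM, which is a limit and not a number. The change to 4-chloro-3-(trifluoromethyl)phenyl on the amide-type nitrogen brings an at least 56-fold higher number from compound 3 to compound 4 (1.74 log units; beyond the scatter) and an at least 2200-fold higher number from compound 2 to compound 4 (3.35 log units; beyond the scatter), so a single change at this place can carry the reading to the top of the measured range, while the earlier compounds had shown only that it could vary widely. The full size of both steps cannot be read, and only their lower bounds are known: the limit of > 20000 nM in this assay, at which 1 of the 4 values shown sits.

Going by these compounds, it remains open whether the chlorine or the trifluoromethyl of the new group goes with this rise. Also open, on these data alone, is how an amine or a carboxylic acid on the phenyl ring at this place would read in this assay.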